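The source may hold more compounds than are shown below. What is called first, only, known or untested is meant among the compounds shown, and "the series" means these compounds.

Measured so far:
compound 1, `CCCCOC(=O)Nc1cc2nc(C3CCCCC3)[nH]c2cc1N(C)C`: > 100 ug/mL
compound 2, `CCCc1ccc(C(=O)Nc2cc3nc(C4CCCCC4)[nH]c3cc2N(C)C)cc1`: > 100 ug/mL
compound 3, `CCCOCC(=O)Nc1cc2nc(C3CCCCC3)[nH]c2cc1N(C)C`: < 50 ug/mL

In an ADME assay on Vero cells (Chlorocebus sabaeus) for cytotoxicity, read by resazurin assay, with a stated time of 3 days (a higher number here means a weaker inhibitor, a lower number a stronger inhibitor), compound 3 gives < 50 ug/mL, which is a limit of the assay and not a number. Going by the values given here, compound 3 is the only one of the three compounds that sits at this limit (the limit of < 50 ug/mL in this assay, at which 1 of the 3 values shown sits). Compound 1 gives > 100 ug/mL, again a limit. Compound 2 gives > 100 ug/mL, also a limit, and both of these two compounds sit at the upper limit (the limit of > 100 ug/mL in this assay, at which 2 of the 3 values shown sit). Of the measured steps, an at least 2.0-fold lower number from compound 1 to compound 3 (0.30 log units; that floor lies within the scatter) and an at least 2.0-fold lower number from compound 2 to compound 3 (0.30 log units; that floor lies within the scatter) both run downward toward the lower limit, whereas a step that the two limits leave unreadable from compound 1 to compound 2.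

Compound 4, `CCc1ccc(C(=O)Nc2cc3nc(C4CCCCC4)[nH]c3cc2N(C)C)cc1`, has not yet been measured. The change from compound 3 is 4-ethylphenyl in place of propoxymethyl on a carbonyl carbon. This is the reverse of the kind of change seen in an at least 2.0-fold lower number from compound 2 to compound 3 (0.30 log units; that floor lies within the scatter), where an aryl group on the carbonyl carbon gave way to the propoxymethyl chain. Compound 4 is therefore expected to move back upward, in the direction of the upper limit, by an estimated step of an at least 2.0-fold higher number from compound 3 to compound 4 (0.30 log units; that floor lies within the scatter). For compound 4 the estimated value is 100 ug/mL, with an expected range from 50 ug/mL to 200 ug/mL.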

Compound 4, half-maximal inhibitory concentration: > 100 ug/mL
Compound 4: a limit, no number (the forecaster's own chance of this, stated with the estimate: 70%); the middle value lies on the limit itself.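

In this assay compound 4 gives > 100 ug/mL, which is a limit of the assay and not a number. Exchanging the propoxymethyl chain on the carbonyl carbon for 4-ethylphenyl gives an at least 2.0-fold higher number from compound 3 to compound 4 (0.30 log units; that floor lies within the scatter), so this direct exchange shows that an aromatic ring at this place can return the value to the upper limit, although the step's floor is small. Shortening the chain on the ring from compound 2 to compound 4 leaves the result at that same limit, and the steps from compound 1 and compound 2 to compound 4 cannot be read, as the compounds share one limit: the limit of > 100 ug/mL in this assay, at which 3 of the 4 values shown sit.

The exchange removes the oxygen of the propoxymethyl chain and brings in the ring at once, so the compounds shown do not separate these two changes; a plain butyl chain on the same carbonyl carbon would bear on that. As far as these compounds go, how far compound 3 and the three compounds at the upper limit really lie apart also stays open, since a limit marks only one side of each true value.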